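The source may hold more compounds than are shown below. What is called first, only, known or untested is meant among the compounds shown, and "the series" means these compounds.

Measured compounds:
- compound 1 `CC(C)CC1n2cncc2CN(Cc2ccc(OC(F)(F)F)cc2)S1(=O)=O`: 0.117 h
- compound 2 `C[C@@H](c1ccc(Cl)cc1)N1Cc2cncn2C(CC2(C)COC2)S1(=O)=O`: 1.27 h
- compound 3 `CC(C)CC1n2cncc2CN(Cc2ccc(F)cc2)S1(=O)=O`: 0.0833 h

In an in vitro ADME assay on microsomes from liver (Homo sapiens) for metabolic stability (on this read-out lower numbers stand for a shorter-lived compound and higher numbers for a longer-lived compound), compound 2 gives the highest number of the three; compound 1 lies below it by a gap beyond the scatter, and compound 3 further still. Going by the values given here, the one measured step, a 1.4-fold lower number from compound 1 to compound 3 (0.15 log units; within the scatter), swaps a group on the aromatic ring and stays within the scatter, so it gives no guide to the change at hand.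

Compound 4 `CC(C)CC1n2cncc2CN([C@@H](C)c2ccc(Cl)cc2)S1(=O)=O` is compound 2 with isopropyl in place of 3-methyloxetan-3-yl on a saturated chain carbon bound to a saturated ring carbon. Among the compounds with values here, no measured pair isolates this change. Within the data shown here, what the numbers do show is that compound 1 and compound 3, which both carry isobutyl at the same position, sit far below compound 2 in this assay, while compound 2, the only one with the oxetane group, stands alone at the top. Compound 4 keeps the chlorophenylethyl group of compound 2 but moves to the isobutyl of compound 1 and compound 3, so a drop of some size is expected rather than none.

The expected step is a 5.1-fold lower number from compound 2 to compound 4 (0.71 log units; beyond the scatter), landing compound 4 between the two groups. Compound 4 is estimated at 0.25 h, with a range of 0.08 h to 0.8 h.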

Compound 4, half-life: 0.1 h
Compound 4: middle estimate off by 2.5-fold (0.40 log units), on the high side, within the range that was stated.
By their numbers in this assay, from the lowest: compounds 3, 4 and 1 (each within the scatter of the next); then compound 2.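

In this assay, going by these compounds alone, the single change of isopropyl in place of 3-methyloxetan-3-yl, on a saturated chain carbon bound to a saturated ring carbon, gives a 13-fold lower number from compound 2 to compound 4 (1.10 log units; beyond the scatter) with the rest of the structure held constant. Compound 1 and compound 3 differ from compound 2 in more than one place, so they could not assign any of the gap to this position, whereas this pair ties a large step to this one change, equally readable as (3-methyloxetan-3-yl)methyl to isobutyl. No measurement on hand bears on the reason for a step of this size.

Still open, from the compounds shown here alone, is which part of the departing group matters: a cyclobutyl or 3-methylazetidin-3-yl group at the same place would separate the ring itself from its oxygen, and a longer chain would test the chain alone. Also open, going by these compounds, is whether the same swap gives a step of similar size when the rest of the molecule is that of compound 1 or compound 3.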